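Swapping the sulfonyl aryl group of compound 1 for methyl

A few compounds are considered here, and "the series" means these few. Any claim that something is new, unique, unknown or untested is made for them only; others in the source may bear on it.

- compound 1 `COc1ncc(-c2ccc3ncnc(Nc4ccc(OCCO)cc4)c3c2)cc1NS(=O)(=O)c1ccc(F)cc1F` gives 2690 nM
- compound 2 `COc1ncc(-c2ccc3ncnc(Nc4ccc(OCCCO)nc4)c3c2)cc1NS(=O)(=O)c1ccc(F)cc1F` gives 9360 nM
- compound 3 `COc1ncc(-c2ccc3ncnc(Nc4ccc(OCCO)c(Cl)c4)c3c2)cc1NS(=O)(=O)c1ccc(F)cc1F` gives 5980 nM

In a functional assay on A549 cells (Homo sapiens) for antiproliferative activity, read by sulforhodamine B assay, with a stated time of 72 h (a higher number here means a weaker inhibitor, a lower number a stronger inhibitor), compound 1 stands lowest of the three (2690 nM). Compound 4 `COc1ncc(-c2ccc3ncnc(Nc4ccc(OCCO)cc4)c3c2)cc1NS(C)(=O)=O` differs from it as follows: methyl in place of 2,4-difluorophenyl on a sulfonyl sulfur. Within the data shown here, no measured step touches this group. Among the measured compounds shown here, the only guides are changes elsewhere in the molecule, a 3.5-fold higher number from compound 1 to compound 2 (0.54 log units; beyond the scatter) and a 2.2-fold higher number from compound 1 to compound 3 (0.35 log units; beyond the scatter), both modest and both upward. The data therefore support only a loose expectation of a higher number, with wide uncertainty. In this assay the estimated step is a 3.0-fold higher number from compound 1 to compound 4 (0.47 log units; beyond the scatter), close in size to the larger measured one. Compound 4 is expected at 8000 nM (range 2500 nM to 26000 nM).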

Compound 4, half-maximal inhibitory concentration: 5200 nM
The estimate for compound 4 lay 1.5-fold (0.19 log units) above the measured number; measured number inside the range.
By their numbers in this assay, from the lowest: compounds 1, 4, 3 and 2 (each within the scatter of the next, the first and the last beyond it).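

In this assay the sulfonyl sulfur accepts methyl in place of 2,4-difluorophenyl with no resolved change, the step being a 1.9-fold higher number from compound 1 to compound 4 (0.29 log units; within the scatter). Among these compounds, the aromatic ring on this sulfur, which the earlier compounds all shared, is therefore not required for activity at this level. No measurement available here accounts for this result.

As far as these compounds go, whether an unsubstituted phenyl, an ethyl or a dimethylamino group on the sulfonyl sulfur would give a different number stays open. Also open, from the compounds shown here alone, is how methyl at this position behaves alongside the changes in compound 2 and compound 3.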